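A few compounds are considered here, and "the series" means these few. Any claim that something is new, unique, unknown or untested is made for them only; others in the source may bear on it.

Compound 1, `COc1ccc2c(c1)c(CCCC(=O)N1CCOCC1)c(C)n2Cc1ccccc1`: 54.2%
Compound 2, `COc1ccc2c(c1)c(CCCC(=O)N1CCOCC1)c(C)n2Cc1ccc(C)cc1`: 26.4%
Compound 3, `COc1ccc2c(c1)c(CCCC(=O)N1CCOCC1)c(C)n2C(=O)c1ccc(Cl)cc1`: 70.2%

In an assay on cells for inhibition of Polyunsaturated fatty acid 5-lipoxygenase (Rattus norvegicus), tested at 5 uM (on this read-out lower numbers stand for less inhibition and higher numbers for more inhibition at the one concentration tested (going by the name of the read-out)), compound 3 gives the highest of the three numbers: it stands a number 16 percentage points higher from compound 1 to compound 3 (beyond the scatter) and a number 43.8 percentage points higher from compound 2 to compound 3 (beyond the scatter), both beyond the scatter. Compound 4, `COc1ccc2[nH]c(C)c(CCCC(=O)N3CCOCC3)c2c1`, has not been measured yet. It differs from compound 3 at the aromatic nitrogen: hydrogen in place of (4-chlorophenyl)carbonyl on an aromatic nitrogen.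

The measured steps bear on this change only in part. Both exchanges at that nitrogen moved the read-out, by a number 16 percentage points higher from compound 1 to compound 3 (beyond the scatter) and by a number 43.8 percentage points higher from compound 2 to compound 3 (beyond the scatter), and the exchange on the benzyl group, a number 27.8 percentage points lower from compound 1 to compound 2 (beyond the scatter), shows that even a small change in that region is felt. Going by the values given here, no measured pair removes the group on the nitrogen altogether, so the direction of that step can only be inferred: the three substituted compounds span a wide range, and the one carrying the (4-chlorophenyl)carbonyl group stands highest. The author therefore expects a loss for compound 4, a step of about a number 35.2 percentage points lower from compound 3 to compound 4 (beyond the scatter), with wide uncertainty. The estimate for compound 4 in this assay is 35%, within a range from 10% to 62%.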

Compound 4, a percentage reported as inhibition, at one concentration (the size of the read-out at that concentration, not a potency): 72.9%
The estimate for compound 4 lay 37.9 percentage points below the measured number; the measured number lies above the stated range.
By their numbers in this assay, from the lowest: compound 2; then compound 1; then compounds 3 and 4 (each within the scatter of the next).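

The result shows that the aromatic nitrogen needs no substituent to keep the read-out in this assay: taking away the (4-chlorophenyl)carbonyl, with its 9 heavy atoms and its six-membered aromatic ring, and leaving hydrogen gives a number 2.7 percentage points higher from compound 3 to compound 4 (within the scatter), so this read-out does not separate that group from hydrogen. The unsubstituted nitrogen also outdoes both benzyl-type groups, with a step of a number 18.7 percentage points higher from compound 1 to compound 4 (beyond the scatter) and another of a number 46.5 percentage points higher from compound 2 to compound 4 (beyond the scatter), so among these four compounds benzyl and 4-methylbenzyl are the substituents that go with lower numbers, while the (4-chlorophenyl)carbonyl of compound 3 goes against any rule that a group on this nitrogen lowers the number. Nothing measured here on the compounds explains these differences.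

Still open, on these data alone, is how a small group such as methyl, or a carbonyl group without the aromatic ring such as acetyl, would behave on this nitrogen, and whether an amine or a carboxylic acid on the benzyl ring would change the picture. With a single tested concentration, the compounds shown also leave open whether compound 3 and compound 4 would stay level across a full range of concentrations.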